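Ether versus ester at the aromatic oxygen

The compounds below may be only part of what the source reports. "The series", "measured", "known", "first", "only" and "open" are said of these compounds alone.

Measured so far in a functional assay on B16 cells (Mus musculus) for antiproliferative activity, read by MTT assay, with a stated time of 24 h; on this read-out lower numbers stand for stronger inhibition and higher numbers for weaker inhibition:
- compound 1 `C#CCOc1ccc2c(=O)c(-c3cc(OC)c(OC)cc3OC)coc2c1` gives 4500 nM
- compound 2 `COc1cccc(C(=O)Oc2ccc3c(=O)c(-c4cc(OC)c(OC)cc4OC)coc3c2)c1` gives > 10000 nM

The value of compound 2 in this assay is a limit of the assay, not a number. Among the measured compounds shown here, compound 2 therefore stands at the weak end of the two values seen; the one measured step, an at least 2.2-fold higher number from compound 1 to compound 2 (0.34 log units; beyond the scatter), is itself only a lower bound because of the limit of > 10000 nM in this assay, at which 1 of the 2 values shown sits.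

Compound 3 `COc1cc(OC)c(-c2coc3cc(OCc4cccc(Br)c4)ccc3c2=O)cc1OC` is not yet measured. Against compound 2 the change is 3-bromobenzyl in place of (3-methoxyphenyl)carbonyl on an oxygen on an aromatic ring. For the measured compounds named here, this reverses the one measured step in kind, since the carbonyl-bearing group leaves and an ether-type substituent returns to the oxygen on the aromatic ring, as in compound 1. Going by these compounds, the expectation is therefore that the number moves back in the direction of compound 1, by a step of an at least 2.0-fold lower number from compound 2 to compound 3 (0.30 log units; that floor lies within the scatter); how far past the limit compound 2 really lies is unknown, so the size is uncertain.

Compound 3 is estimated at 5000 nM in this assay, with a range of 1500 nM to 15000 nM.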

Compound 3, half-maximal inhibitory concentration: 4400 nM
Compound 3: the middle estimate sits 1.1-fold (0.06 log units) above what was measured; measured number inside the range.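

In this assay, 3-bromobenzyl in place of (3-methoxyphenyl)carbonyl on the oxygen gives an at least 2.2-fold lower number from compound 2 to compound 3 (0.35 log units; beyond the scatter), so a substituent with a six-membered aromatic ring of carbon only can sit on this oxygen without the weak reading of compound 2, at least when it is attached as in compound 3. Against the propargyl ether, 3-bromophenyl in place of ethynyl on the saturated chain carbon gives a 1.0-fold lower number from compound 1 to compound 3 (0.01 log units; within the scatter), so compound 1 and compound 3 cannot be told apart here, and the larger ether substituent shows no loss against the smaller one. The value of compound 2 is a limit of the assay and not a number, so the step into compound 3 is only a floor and its true size stays unknown: the limit of > 10000 nM in this assay, at which 1 of the 3 values shown sits.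

Between compound 2 and compound 3 the carbonyl and the ring substituent change together, so the shown values do not say which of the two carries the step; a 3-bromobenzoyl ester or a 3-methoxybenzyl ether would separate them. Also open, going by these compounds, is how this oxygen would read with a substituent ending in an amine or a carboxylic acid, or with a longer chain.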